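The source may report more compounds than this note shows. Statements on the series, on what has been measured and on what is new or still open speak of the compounds shown alone.

Within the data shown here, compound 1 `COc1ccc(Cn2cc(CNC(=O)c3cn(-c4ccccc4)nc3-c3ccccc3)nn2)cc1OC` is the only compound with a number rather than a limit: in a functional assay on HeLa cells (Homo sapiens) for antiproliferative activity, read by sulforhodamine B assay, with a stated time of 48 h (a higher number here means a weaker inhibitor of growth, a lower number a stronger inhibitor of growth), compound 1 gives 10800 nM. Compound 2 `COc1cc(Cn2cc(CNC(=O)c3cn(-c4ccccc4)nc3-c3ccccc3)nn2)cc(OC)c1OC` reaches only a limit of this assay, > 100000 nM. Compound 3 `COc1ccc(Cn2cc(CNC(=O)c3cn(-c4ccccc4)nc3-c3ccc(F)cc3)nn2)cc1OC` differs from compound 1 by fluoro in place of hydrogen on an aromatic carbon. Among the measured compounds shown here, the one measured step, an at least 9.2-fold higher number from compound 1 to compound 2 (0.96 log units; beyond the scatter), concerns a methoxy in place of hydrogen, a different change, so no measured step bears on the fluoro substitution. The expected step, no change at the digits printed from compound 1 to compound 3 (within the scatter), is therefore none beyond the scatter. Compound 3 is estimated at 10800 nM, between 4000 nM and 30000 nM.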

Compound 3, concentration for 50% growth inhibition: 200 nM
The estimate for compound 3 lay 54-fold (1.73 log units) above the measured number; the whole stated range lies above it.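

Changing phenyl to 4-fluorophenyl gives a 54-fold lower number from compound 1 to compound 3 (1.73 log units; beyond the scatter) in this assay, so this place, on a six-membered aromatic ring of carbon only and para to a large group, responds strongly to a single fluoro. The earlier step, a methoxy in place of hydrogen elsewhere on the molecule, went only toward weaker growth inhibition; this one shows that a single substitution on the shared core can also strengthen it. Nothing shown accounts for the size of this step.

Going by these compounds, whether the gain belongs to fluoro alone stays open: chloro, methyl or an amine at this same place would settle that. On these data alone, whether fluoro acts alike on the other phenyl group also remains unknown.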